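Swapping Methoxy for Methyl at the Assay Limit

The source may hold more compounds than are shown below. What is called first, only, known or untested is meant among the compounds shown, and "the series" means these compounds.

In a functional assay on L1210 cells (Mus musculus) for antiproliferative activity (a higher number here means a weaker inhibitor, a lower number a stronger inhibitor), compound 1 (`COc1ccc(OC)c2c(O)ccnc12`) gives > 40000 nM as a limit, not a number. Compound 2 (`COc1cc2nccc(O)c2c(OC)c1OC`) gives > 40000 nM as a limit too. Compound 3 (`COc1cc(O)c2c(O)ccnc2c1`) gives > 40000 nM as a limit as well. Compound 1 therefore stands with the other two at the same limit (the limit of > 40000 nM in this assay, at which 3 of the 3 values shown sit), and no true number is known for any of them. Compound 4 (`COc1ccc(C)c2nccc(O)c12`) alters compound 1 in one place: methyl in place of methoxy on an aromatic carbon. Among the measured compounds shown here, no measured pair shows what such a swap does in this assay, so the change expected is none beyond the scatter. The estimated step (a number no higher from compound 1 to compound 4 (the limit leaves the size open)) is accordingly small. Compound 4 is expected near 40000 nM (estimated range 15000 nM to 80000 nM).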

Compound 4, half-maximal inhibitory concentration: > 40000 nM
Compound 4: no number, only a limit; the forecaster's own chance of this, stated with the estimate: 75%; the middle value lies on the limit itself.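

Among the compounds shown here, no step from compound 1 to compound 4 can be read, as each gives only a limit: the limit of > 40000 nM in this assay, at which 4 of the 4 values shown sit. The compounds shown leave open whether methyl in place of methoxy changes the true potency in this assay at all.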